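The source may report more compounds than this note shows. Statements on the series, on what has been measured and on what is new or still open speak of the compounds shown alone.

Compound 3, whose structure is `CCOc1ccc(NC2=C(C(=O)c3ccccc3)C(c3ccc(Br)cc3)N(CCCn3ccnc3)C2=O)cc1`, stands highest of the three numbers in a functional assay on SAOS-2 cells (Homo sapiens) for antiproliferative activity, read by MTT assay, with a stated time of 72 h (a higher number here means a weaker inhibitor, a lower number a stronger inhibitor), where compound 3 gives 30900 nM. Compound 1 `CCCCCOC1=C(C(=O)c2ccccc2)C(c2ccc(Br)cc2)N(CCCn2ccnc2)C1=O` gives 9990 nM, and compound 2 `O=C(C1=C(Nc2ccccc2)C(=O)N(CCCn2ccnc2)C1c1ccc(Br)cc1)c1ccccc1` gives 24400 nM. The steps of a 2.4-fold higher number from compound 1 to compound 2 (0.39 log units; beyond the scatter) and a 3.1-fold higher number from compound 1 to compound 3 (0.49 log units; beyond the scatter) are modest; the step of a 1.3-fold higher number from compound 2 to compound 3 (0.10 log units; within the scatter) is within the scatter. Compound 4 `O=C(C1=C(Nc2ccc(I)cc2)C(=O)N(CCCn2ccnc2)C1c1ccc(Br)cc1)c1ccccc1` differs from compound 3 by iodo in place of ethoxy on an aromatic carbon. Within the data shown here, only the step from compound 2 to compound 3 bears on this change, since it also alters the aromatic carbon on the amino-bearing phenyl, and it was within the scatter. Compound 4 is therefore expected to show a 1.1-fold lower number from compound 3 to compound 4 (0.04 log units; within the scatter), with an estimate of 28000 nM in this assay, ranging from 14000 nM to 60000 nM.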

Compound 4, half-maximal inhibitory concentration: 23400 nM
Compound 4: the middle estimate sits 1.2-fold (0.08 log units) above what was measured, and the stated range covers the measured number.
By their numbers in this assay, from the lowest: compound 1; then compounds 4, 2 and 3 (each within the scatter of the next).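

In this assay, iodo in place of ethoxy para to a large group gives a 1.3-fold lower number from compound 3 to compound 4 (0.12 log units; within the scatter) and iodo in place of hydrogen gives a 1.0-fold lower number from compound 2 to compound 4 (0.02 log units; within the scatter) so hydrogen, ethoxy and iodo at this place cannot be told apart. Against pentyloxy, (4-iodophenyl)amino gives a 2.3-fold higher number from compound 1 to compound 4 (0.37 log units; beyond the scatter) and so joins the other two amino groups on the far side of that gap. Nothing measured here accounts for these numbers. Still open, going by these compounds, is whether an amine or a carboxylic acid at this place on the phenyl ring would leave the number as little changed. Also open, on these data alone, is how a butoxy or hexyloxy chain would compare with pentyloxy.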